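Swapping a pyrrolidine amide for a morpholine amide

The source may report more compounds than this note shows. Statements on the series, on what has been measured and on what is new or still open speak of the compounds shown alone.

Of the compounds shown here, three sharing one core have been tested in a functional assay on PC-3 cells (Homo sapiens) for inhibition, read by MTT assay, with a stated time of 48 h; a lower number here means a stronger inhibitor, a higher number a weaker inhibitor. Compound 1 `CCn1c(/C=C2\SC(=O)N(CC(=O)Nc3cc(C(C)(C)C)on3)C2=O)nc2ccccc21` gives a value that is only a limit of the assay, > 50000 nM. Compound 2 `CCn1c(/C=C2\SC(=O)N(CC(=O)N3CCCC3)C2=O)nc2ccccc21` likewise gives only a limit, > 50000 nM. Compound 3 `CC(C)n1c(/C=C2\SC(=O)N(CC(=O)N3CCCC3)C2=O)nc2ccccc21` also reaches no more than a limit, > 50000 nM. Compound 2 therefore stands at the same limit as the other two, and nothing among the numbers shown separates it from them, as summed up by the limit of > 50000 nM in this assay, at which 3 of the 3 values shown sit.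

The unmeasured compound 4 `CCn1c(/C=C2\SC(=O)N(CC(=O)N3CCOCC3)C2=O)nc2ccccc21` differs from compound 2 in one place: morpholin-4-yl in place of pyrrolidin-1-yl on a carbonyl carbon.

Among the compounds with values here, two measured steps touch the same part of the molecule. The step that the two limits leave unreadable from compound 1 to compound 2 changes the group on the carbonyl carbon, and the step that the two limits leave unreadable from compound 2 to compound 3 alters the chain carbon bound to the aromatic nitrogen. Both are unreadable in size. Every value involved is a limit. Within the data shown here, no step with a readable size is available, so the expectation for compound 4 rests only on the observation that each measured change left the value at the limit.

Compound 4 is expected to behave the same way, with an estimated step that the limit leaves unreadable from compound 2 to compound 4 in this assay. The estimated value for compound 4 is 70000 nM, with a likely range from 25000 nM to 250000 nM, and most probably the assay again reports only a limit.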

Compound 4, half-maximal inhibitory concentration: > 50000 nM
Compound 4: no number, only a limit; the forecaster's own chance of this, stated with the estimate: 85%; the middle value does not contradict the limit.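

Going by these compounds, no new step can be read: compound 4, like compound 1 and compound 2, gives only a limit in this assay, so the size of the change from either of them to compound 4 stays unknown. All the values agree on this: the limit of > 50000 nM in this assay, at which 4 of the 4 values shown sit.

The compounds shown leave open whether morpholin-4-yl and pyrrolidin-1-yl on the carbonyl carbon differ at all in this assay.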